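This account rests on a few compounds, and the source may have more. Where it says the series, first, only, none or still open, it means among the compounds named here.

Compound 2 `CC(C)NC(=O)N1CCN(C(=S)SCc2cn(Cc3ccccc3F)nn2)CC1` stands lowest of the two numbers in a functional assay on MCF7 cells (Homo sapiens) for cytotoxicity, read by MTT assay, with a stated time of 72 h (on this read-out lower numbers stand for stronger inhibition and higher numbers for weaker inhibition), where compound 2 gives 1860 nM. Compound 3 `O=C(NC1CCCCC1)N1CCN(C(=S)SCc2cn(Cc3ccccc3F)nn2)CC1` gives 85000 nM in this assay, a 46-fold higher number from compound 2 to compound 3 (1.66 log units; beyond the scatter). Compound 1 `NC(=O)N1CCN(C(=S)SCc2cn(Cc3ccccc3F)nn2)CC1` reaches only a limit in this assay, > 128000 nM. Compound 4 `Cc1ccc(Cn2cc(CSC(=S)N3CCN(C(=O)NC(C)C)CC3)nn2)cc1` differs from compound 2 in 4-methylphenyl in place of 2-fluorophenyl on a saturated chain carbon bound to an aromatic nitrogen. Going by the values given here, the measured steps all alter the group on the amide-type nitrogen: an at least 68-fold lower number from compound 1 to compound 2 (1.83 log units; beyond the scatter), an at least 1.5-fold lower number from compound 1 to compound 3 (0.17 log units; that floor lies within the scatter) and a 46-fold higher number from compound 2 to compound 3 (1.66 log units; beyond the scatter); none touches the benzyl substituent, so no measured step bears directly on the change to compound 4. The expected step of a 1.2-fold higher number from compound 2 to compound 4 (0.07 log units; within the scatter) is therefore none beyond the scatter. Compound 4 is estimated at 2200 nM in this assay, with a range from 600 nM to 8000 nM.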

Compound 4, half-maximal inhibitory concentration: 4630 nM
Beside the measured number, compound 4's estimate is 2.1-fold (0.32 log units) below it, within the range that was stated.
By their numbers in this assay, from the lowest: compound 2; then compound 4; then compound 3. At a limit, above all of these: compound 1.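

Going by these compounds alone, the benzyl position, untouched by the earlier steps, also moves the number in this assay: 4-methylphenyl in place of 2-fluorophenyl on a saturated chain carbon bound to an aromatic nitrogen gives a 2.5-fold higher number from compound 2 to compound 4 (0.40 log units; beyond the scatter), a modest step beside the large ones on the amide-type nitrogen. Compound 2 keeps the lowest number of the series.

This change alters both the substituent and where it sits on the phenyl, so the two remain inseparable; a plain phenyl or a 4-fluorophenyl would separate them. Nothing measured here explains the step.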